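This account rests on a few compounds, and the source may have more. Where it says the series, first, only, none or still open, it means among the compounds named here.

Compound 1 `COc1cc(OC)c(OC)cc1/C=C/C(=O)c1ccc(O)cc1` was tested in a functional assay on cells (Erythrocyte, Rattus norvegicus) for inhibition, read by hemolysis, with a stated time of 1 h (on this read-out higher numbers stand for weaker inhibition and lower numbers for stronger inhibition), and gave 2.29 ug/mL. Compound 2 `COc1cc(C(=O)/C=C/c2cc(OC)c(OC)cc2OC)ccc1O` gave 2.16 ug/mL in this assay, and the step of a 1.1-fold lower number from compound 1 to compound 2 (0.03 log units; within the scatter) leaves the two numbers within the scatter of each other, so neither stands apart. Compound 3 `COc1cc(OC)c(OC)cc1/C=C/C(=O)c1ccccc1` has not yet been measured; it differs from compound 1 by hydrogen in place of hydroxy on an aromatic carbon. Among the compounds with values here, no measured step touches this hydroxy, and the only known step, a 1.1-fold lower number from compound 1 to compound 2 (0.03 log units; within the scatter), stayed within the scatter, so no step beyond the scatter is expected here. Compound 3 is therefore estimated to give 2.6 ug/mL, between 1.2 ug/mL and 5.5 ug/mL, a step of a 1.1-fold higher number from compound 1 to compound 3 (0.06 log units; within the scatter) that is expected to remain within the scatter.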

Compound 3, half-maximal inhibitory concentration: 2.23 ug/mL
For compound 3 the middle estimate is 1.2-fold (0.07 log units) above the measured one; measured number inside the range.
By their numbers in this assay, from the lowest: compounds 2, 3 and 1 (each within the scatter of the next).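

Swapping hydroxy for hydrogen on the aromatic ring, the change from 4-hydroxyphenyl to phenyl, gives a 1.0-fold lower number from compound 1 to compound 3 (0.01 log units; within the scatter) in this assay. The hydroxy at this position is therefore not required for the inhibition seen on this read-out, which compounds that all carry it could not show. No supporting data here offer an explanation for this result.

Still open, as far as these compounds go, is whether an amine, a carboxylic acid or a longer chain such as butoxy at this same place would also leave the number within the scatter.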